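Replacing the side chain of compound 1 with isopropyl

A few compounds are considered here, and "the series" means these few. Any claim that something is new, unique, unknown or untested is made for them only; others in the source may bear on it.

Compound 1, `N=C(N)NCCC[C@H](NC(=O)CN(c1nc(Cl)nc2[nH]cnc12)C1CC1)C(=O)O`, is the stronger of the two measured compounds: in a functional assay on the whole organism (Tail, strain ICR) with Mus musculus as the target, in the tail flick test, with a stated time of 30 min, at a dose of 25 umol/kg by the oral route (on this read-out higher numbers stand for a stronger effect at the one dose given and lower numbers for a weaker effect), compound 1 gives 45.4%. Among the measured compounds shown here, the only other measured compound, compound 2, `CC[C@H](C)[C@H](NC(=O)CN(c1ncnc2c1ncn2C1CCCCO1)C1CC1)C(=O)OCc1ccccc1`, has a different core and an ester instead of the free acid, and in this assay compound 2 gives 25.6%, a gap beyond the usual scatter. For the measured compounds named here, no pair of measured compounds differs in a single place, so no measured step is available to lean on.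

Compound 3, `CC(C)[C@H](NC(=O)CN(c1nc(Cl)nc2[nH]cnc12)C1CC1)C(=O)O`, keeps the core and the free acid of compound 1 and differs from it only as follows: a group of 3 heavy atoms (3 carbon; no ring) in place of a group of 7 heavy atoms (4 carbon, 3 nitrogen; no ring), on a saturated chain carbon bound to an amide-type nitrogen and a carbonyl carbon. The group of 3 heavy atoms (3 carbon; no ring) that enters carries no hydrogen-bond donor or acceptor, whereas the group of 7 heavy atoms (4 carbon, 3 nitrogen; no ring) that leaves carries three donors and one acceptor. With no measured step of this kind in hand, a decrease beyond the scatter is expected, of the size given by a number 15.4 percentage points lower from compound 1 to compound 3 (beyond the scatter). Compound 3 is therefore estimated at 30% in this assay, within a range from 10% to 52%.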

Compound 3, a percentage reported as activity, at one dose (the size of the read-out at that dose, not a potency): 31.2%
The estimate for compound 3 lay 1.2 percentage points below the measured number, and the stated range covers the measured number.
By their numbers in this assay, from the lowest: compounds 2 and 3 (each within the scatter of the next); then compound 1.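

At the saturated chain carbon bound to an amide-type nitrogen and a carbonyl carbon, the series now has its first single-place comparison: with the core and the free acid held constant, isopropyl in place of the group of 7 heavy atoms gives a number 14.2 percentage points lower from compound 1 to compound 3 (beyond the scatter) in this assay at the one dose tested. The read-out therefore depends on the group at this position, although the nitrogen-free isopropyl group does not remove it, as compound 3 still gives 31.2% here. No available measurement accounts for this step.

This single step does not separate the effect of chain length from that of the nitrogens in the group that leaves. On these data alone, it remains open whether a primary amine on a chain, or a longer alkyl chain without nitrogen, would bring the read-out closer to that of compound 1.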